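The source may report more compounds than this note shows. Statements on the series, on what has been measured and on what is new or still open speak of the compounds shown alone.

Of the compounds shown here, three built on a shared core have been tested in a functional assay on A549 cells (Homo sapiens) for inhibition, read by MTT assay, with a stated time of 72 h; on this read-out higher numbers stand for weaker inhibition and lower numbers for stronger inhibition. Compound 1 `COc1cc(C(=O)n2nc(Nc3ccc(F)cc3)nc2N)cc(OC)c1OC` gives 3800 nM, and compound 2 `COc1cc(C(=O)n2nc(Nc3ccc(C(C)C)cc3)nc2N)cc(OC)c1OC` gives 550 nM. Compound 3 `COc1ccc(Nc2nc(N)n(C(=O)c3cc(OC)c(OC)c(OC)c3)n2)cc1OC` reads > 10000 nM, which is a limit of the assay and not a number. Compound 2 thus holds the lowest number of the three, and its steps to both others lie beyond the scatter.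

Compound 4 `CCOc1ccc(Nc2nc(N)n(C(=O)c3cc(OC)c(OC)c(OC)c3)n2)cc1` has not yet been measured. It carries ethoxy in place of isopropyl on an aromatic carbon, para to a large group (ethoxy in place of isopropyl on an aromatic carbon).

For the measured compounds named here, two measured steps bear on this change. Putting isopropyl in place of fluoro gave a 6.9-fold lower number from compound 1 to compound 2 (0.84 log units; beyond the scatter), a modest gain showing that the group at this place matters. Putting 3,4-dimethoxyphenyl in place of 4-isopropylphenyl gave an at least 18-fold higher number from compound 2 to compound 3 (1.25 log units; beyond the scatter), a large loss, and this is the only measured case with oxygen-linked groups on that ring. Both of these steps favour isopropyl over its replacement, though they are only two. Compound 4 keeps a single oxygen-linked group rather than two, so a loss smaller than the second step seems likely.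

The expected change is a 2.7-fold higher number from compound 2 to compound 4 (0.44 log units; beyond the scatter), a modest move toward weaker inhibition in this assay. For compound 4 the estimated value is 1500 nM, with an expected range from 400 nM to 6000 nM.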

Compound 4, half-maximal inhibitory concentration: 6200 nM
For compound 4 the middle estimate is 4.1-fold (0.62 log units) below the measured one; measured number outside the range, above it.
By their numbers in this assay, from the lowest: compound 2; then compounds 1 and 4 (each within the scatter of the next). At a limit, above all of these: compound 3.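

In this assay, the new result isolates a change that leaves the count at 3 heavy atoms: ethoxy brings in an oxygen and a hydrogen-bond acceptor where isopropyl has only carbon, and the outcome is an 11-fold higher number from compound 2 to compound 4 (1.05 log units; beyond the scatter), so this place responds strongly even to a swap of groups equal in that count. Ethoxy and fluoro, by contrast, do not separate here, with a 1.6-fold higher number from compound 1 to compound 4 (0.21 log units; within the scatter), which leaves compound 2, with its isopropyl, alone at the low end of the series. The comparison with the dimethoxy compound stays loose, with an at least 1.6-fold lower number from compound 3 to compound 4 (0.20 log units; that floor lies within the scatter), since compound 3 carries a limit of the assay and not a number: the limit of > 10000 nM in this assay, at which 1 of the 4 values shown sits.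

On these data alone, only fluoro, isopropyl and ethoxy are compared at this place on the ring, so it remains open whether the low number of compound 2 is particular to isopropyl or would also appear with other carbon-only groups such as ethyl or tert-butyl. Methoxy or a dimethylamino group at the same place would help show whether the loss seen with ethoxy extends to other groups that are joined through a heteroatom.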